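From piperazin-1-yl to 1,1-dioxothiomorpholin-4-yl on the carbonyl

The source may hold more compounds than are shown below. What is called first, only, known or untested is meant among the compounds shown, and "the series" means these compounds.

In a functional assay on A20 cells (Mus musculus) for inhibition, with stated times of 1 h, 16 h and 24 h (a lower number here means a stronger inhibitor, a higher number a weaker inhibitor), compound 1 `CC1CCN(C(=O)[C@@H]2C[C@H](S(=O)(=O)c3ccccc3)C[C@H]2C(=O)NC2(C#N)CC2)CC1` gives 2 nM and compound 2 `N#CC1(NC(=O)[C@@H]2C[C@@H](S(=O)(=O)c3ccccc3)C[C@H]2C(=O)N2CCNCC2)CC1` gives 1340 nM as the higher of the two numbers. Compound 3 `N#CC1(NC(=O)[C@@H]2C[C@@H](S(=O)(=O)c3ccccc3)C[C@H]2C(=O)N2CCS(=O)(=O)CC2)CC1` has 1,1-dioxothiomorpholin-4-yl in place of piperazin-1-yl on a carbonyl carbon is the full difference from compound 2. Among the compounds with values here, one measured step bears on this change: a 670-fold higher number from compound 1 to compound 2 (2.83 log units; beyond the scatter) is large and beyond the scatter, with piperazin-1-yl in place of 4-methylpiperidin-1-yl on a carbonyl carbon. Within the data shown here, no measured compound carries 1,1-dioxothiomorpholin-4-yl, so the size of any recovery remains open. Given a 670-fold higher number from compound 1 to compound 2 (2.83 log units; beyond the scatter) as the only guide, a partial return is expected. The expected change is an 8.9-fold lower number from compound 2 to compound 3 (0.95 log units; beyond the scatter) and points to a lower number. In this assay compound 3 is estimated at 150 nM with 20 nM to 1000 nM as the expected range.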

Compound 3, half-maximal inhibitory concentration: 816 nM
For compound 3 the middle estimate is 5.4-fold (0.74 log units) below the measured one; low and high end bracket the measured number.
By their numbers in this assay, from the lowest: compound 1; then compounds 3 and 2 (each within the scatter of the next).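

In this assay, the exchange on the carbonyl carbon gives a 1.6-fold lower number from compound 2 to compound 3 (0.22 log units; within the scatter), so 1,1-dioxothiomorpholin-4-yl and piperazin-1-yl do not separate at this position, even though the hydrogen-bond donor of piperazin-1-yl is gone and the entering ring brings two double bonds. The comparison with the 4-methylpiperidin-1-yl amide, a 410-fold higher number from compound 1 to compound 3 (2.61 log units; beyond the scatter), shows that a second ring replacement stays far from compound 1, so the large gap at this position is not specific to piperazin-1-yl. Nothing available accounts for these numbers. Going by these compounds, whether the gap follows the methyl group or the second ring hetero atom stays open. Plain piperidin-1-yl and 4-methylpiperazin-1-yl on the same carbonyl carbon would separate those two features.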